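Nitro to Amino on Two Related Sulfone Scaffolds

A few compounds are considered here, and "the series" means these few. Any claim that something is new, unique, unknown or untested is made for them only; others in the source may bear on it.

Compound 1 `COc1ccc(CS(=O)(=O)/C=C/c2c(OC)cccc2OC)c([N+](=O)[O-])c1` gives 50000 nM in a functional assay on DU-145 cells (Homo sapiens) for cytotoxicity, read by trypan blue exclusion, with a stated time of 96 h; on this read-out higher numbers stand for weaker inhibition and lower numbers for stronger inhibition. Compound 2 `COc1ccc(CS(=O)(=O)/C=C/c2c(OC)cccc2OC)c(N)c1` gives 750 nM in this assay. The step of a 67-fold lower number from compound 1 to compound 2 (1.82 log units; beyond the scatter) follows this change: amino in place of nitro on an aromatic carbon. Compound 3 `COc1cc(OC)c(/C=C/S(=O)(=O)Cc2ccc(Br)c([N+](=O)[O-])c2)c(OC)c1` gives 25000 nM in this assay; the difference between the core of compound 3 and the core of compound 1 is not broken down here. Compound 4 `COc1cc(OC)c(/C=C/S(=O)(=O)Cc2ccc(Br)c(N)c2)c(OC)c1` differs from compound 3 by amino in place of nitro on an aromatic carbon. This is the same kind of change as from compound 1 to compound 2, but the place differs: in compound 4 the amino sits ortho to a bromo group and meta to a large group, whereas in compound 2 it sits ortho to a large group and meta to a methoxy group. Compound 4 is expected to show a step of a 21-fold lower number from compound 3 to compound 4 (1.32 log units; beyond the scatter), somewhat smaller than a 67-fold lower number from compound 1 to compound 2 (1.82 log units; beyond the scatter). The estimate for compound 4 is 1200 nM, between 300 nM and 6000 nM.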

Compound 4, half-maximal inhibitory concentration: 750 nM
Compound 4: the middle estimate sits 1.6-fold (0.20 log units) above what was measured, and the stated range covers the measured number.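

Amino in place of nitro on an aromatic carbon again gives a large step in this assay, here a 33-fold lower number from compound 3 to compound 4 (1.52 log units; beyond the scatter). The change carries over from one core to the other in direction, and the two steps do not differ in size beyond the scatter: the same change on two cores in this assay, a 67-fold lower number (1.82 log units; beyond the scatter) from compound 1 to compound 2 and a 33-fold lower number (1.52 log units; beyond the scatter) from compound 3 to compound 4, 2.0-fold (0.30 log units) apart, within the scatter of two such steps. This rests on two pairs only, so it does not show that the change would hold on any further core, nor does it explain why amino gives the lower number.

The compounds shown leave open whether a hydroxyl or an acetamide on the same aromatic carbon would give numbers like those of the amino or the nitro compounds. They also leave open how a chloro group in place of the bromo group would affect the step.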